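The compounds below may be only part of what the source reports. "The series", "measured", "known", "first", "only" and "open" are said of these compounds alone.

Measured so far:
- compound 1, `COc1ccc(/C=C/C(=O)c2ccc(OC)c(OC)c2)cc1`: 93.1%
- compound 2, `COc1ccc(/C=C/C(=O)c2ccc(OC)c(OC)c2)cc1OC`: 91.9%
- compound 3, `COc1ccc(/C=C/C(=O)c2ccc(OC)c(OC)c2)cc1O`: 82.1%

In an ADME assay on RAW264.7 cells (Mus musculus) for cytotoxicity, read by MTT assay, with a stated time of 24 h, tested at 2.5 ug/mL (on this read-out higher numbers stand for a weaker effect at the one concentration tested and lower numbers for a stronger effect), compound 1 stands highest of the three numbers. Its nearest neighbour is compound 2, a step of a number 1.2 percentage points lower from compound 1 to compound 2 (within the scatter); its furthest is compound 3, a step of a number 11 percentage points lower from compound 1 to compound 3 (beyond the scatter). Compound 2 and compound 3 differ by a number 9.8 percentage points lower from compound 2 to compound 3 (within the scatter).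

Compound 4, `COc1ccc(/C=C/C(=O)c2ccc(O)c(OC)c2)cc1`, has not yet been measured in this assay. It differs from compound 1 by hydrogen in place of methyl on an oxygen on an aromatic ring.

For the measured compounds named here, the step that bears most directly on this change is the one from compound 2 to compound 3, where the same kind of change on the other aromatic ring gave a number 9.8 percentage points lower from compound 2 to compound 3 (within the scatter). The step from compound 1 to compound 3, which introduces a hydroxy group, gave a number 11 percentage points lower from compound 1 to compound 3 (beyond the scatter). Both point the same way, so a small downward step in this assay is expected for compound 4, near the edge of the scatter.

For compound 4 in this assay the expected step from compound 1 is a number 8.1 percentage points lower from compound 1 to compound 4 (within the scatter). Compound 4 is therefore estimated at 85%, within a range from 74% to 95%.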

Compound 4, a percentage reported as activity, at one concentration (the size of the read-out at that concentration, not a potency): 96%
Estimate against measurement, compound 4: 11 percentage points below; measured number outside the range, above it.
By their numbers in this assay, from the lowest: compounds 3, 2, 1 and 4 (each within the scatter of the next, the first and the last beyond it).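

In this assay, methoxy to hydroxy on this oxygen on an aromatic ring gives a number 2.9 percentage points higher from compound 1 to compound 4 (within the scatter), so the hydroxy group at this place leaves the read-out within the scatter of the methoxy parent. The earlier compounds shown here showed this change at only one other place, and the two places are not separated by the data: the same change on two cores in this assay, a number 9.8 percentage points lower (within the scatter) from compound 2 to compound 3 and a number 2.9 percentage points higher (within the scatter) from compound 1 to compound 4, 12.7 percentage points apart, within the scatter of two such steps. A lower number does not go with every hydroxy group in this series. The step of a number 11 percentage points lower from compound 1 to compound 3 (beyond the scatter) lies beyond the scatter, but compound 4 goes against that pattern.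

On these data alone, whether an ethoxy group or a longer chain on this oxygen, or an amine in its place, would stay within the same scatter remains open. With a single concentration tested, the behaviour of these compounds at higher concentrations also remains open.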